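One Methyl Fewer on the Amide of Compound 1

The source may report more compounds than this note shows. Statements on the series, on what has been measured and on what is new or still open speak of the compounds shown alone.

Of the compounds shown here, three built on a shared core have been measured in an assay on HEK293 cells for antagonist activity at transient receptor potential cation channel subfamily M member 8 (Homo sapiens), read by calcium flux; a higher number here means a weaker inhibitor, a lower number a stronger inhibitor. Compound 1, `COc1cccc(CN(C(=O)c2ccccc2)[C@@H](C(=O)N(C)C)c2ccccc2)c1`, gives 86000 nM in this assay, the highest of the three numbers. Compound 3, `COc1cccc(CN(C(=O)c2ccccc2)C(C(=O)O)c2ccccc2)c1`, gives 59000 nM in this assay, a number that sits within the usual scatter of the number for compound 1, so the two cannot be told apart. Compound 2, `COc1cccc(CN(C(=O)c2cccs2)[C@@H](C(N)=O)c2ccccc2)c1`, gives 1700 nM in this assay, a far lower number; its structure differs from compound 1 in more than one place, so no single change can be credited for that gap.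

Compound 4, `CNC(=O)[C@@H](c1ccccc1)N(Cc1cccc(OC)c1)C(=O)c1ccccc1`, is compound 1 with one change: hydrogen in place of methyl on an amide-type nitrogen. Among the measured compounds shown here, no pair of measured compounds isolates this change. The nearest guide is compound 2, whose 1700 nM shows that a different amide can sit alongside a much stronger inhibitor, though other differences are bundled into that comparison. On that thin basis a moderate step toward a lower number, beyond the scatter, is expected for compound 4 rather than no change at all. Compound 4 is estimated to give 20000 nM in this assay, within a range from 5000 nM to 60000 nM, an expected step of a 4.3-fold lower number from compound 1 to compound 4 (0.63 log units; beyond the scatter).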

Compound 4, half-maximal inhibitory concentration: 10000 nM
The estimate for compound 4 lay 2.0-fold (0.30 log units) above the measured number; the measured number falls inside the stated range.
By their numbers in this assay, from the lowest: compound 2; then compound 4; then compounds 3 and 1 (each within the scatter of the next).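

Taking one methyl off the amide-type nitrogen, so that dimethylcarbamoyl becomes methylcarbamoyl, gives an 8.6-fold lower number from compound 1 to compound 4 (0.93 log units; beyond the scatter) in this assay. Among the compounds shown here, this is the first pair that differs in one place only, so this step, unlike the gaps among the earlier compounds, can be credited to a single change. It shows that the number read in this assay responds to the loss of just one carbon atom at this nitrogen, even though the rest of the structure stays the same. Nothing available here explains why the number moves by this much, so the step stands as an observation without a known cause.

A single step cannot show whether the trend continues, so the compounds shown leave open what a second hydrogen in place of the remaining methyl would do on the core of compound 4. They also leave open how an ethyl group or a longer chain on this same nitrogen would compare with the methyl of compound 4.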